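From Phenyl to Chloro: Expecting Potency to Return

The compounds below may be only part of what the source reports. "The series", "measured", "known", "first", "only" and "open" are said of these compounds alone.

Compound 2 `O=C(/C=C/c1ccc(-c2ccccc2)cc1)Nc1ccc2c(c1)OCCO2` reaches only the limit of > 4000 nM in a functional assay on CHO cells for inhibition of transient receptor potential cation channel subfamily V member 1 (Homo sapiens); a lower number here means a stronger inhibitor, a higher number a weaker inhibitor. Compound 3 `O=C(/C=C/c1ccc(Cl)cc1)Nc1ccc2c(c1)OCCO2` carries chloro in place of phenyl on an aromatic carbon. Among the measured compounds shown here, one measured step bears on this: compound 1 `Cc1ccc(/C=C/C(=O)Nc2ccc3c(c2)OCCO3)cc1` gives 210 nM in this assay, and an at least 19-fold higher number from compound 1 to compound 2 (1.27 log units; beyond the scatter). From the compounds shown here alone, because the limit of > 4000 nM in this assay, at which 1 of the 2 values shown sits, caps that step, its true size stays unknown. Chloro brings one heavy atom where phenyl brought six, so the change should largely undo that loss. Compound 3 is therefore expected to show a step of an at least 16-fold lower number from compound 2 to compound 3 (1.20 log units; beyond the scatter). The estimate for compound 3 is 250 nM, with a range from 80 nM to 800 nM.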

Compound 3, half-maximal inhibitory concentration: 250 nM
Beside the measured number, compound 3's estimate shows no gap at the digits printed; the range from low to high includes it.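

Replacing phenyl with chloro at this position gives an at least 16-fold lower number from compound 2 to compound 3 (1.20 log units; beyond the scatter) in this assay, so the core of compound 3 keeps its inhibition when the large phenyl is absent. Chloro and methyl cannot be told apart here, with a 1.2-fold higher number from compound 1 to compound 3 (0.08 log units; within the scatter). The first step has no exact size, because compound 2 gives only a limit: the limit of > 4000 nM in this assay, at which 1 of the 3 values shown sits.

From the compounds shown here alone, whether an ethyl group or a longer chain would stay with methyl and chloro or fall towards phenyl remains open. So does the effect of an amine or a carboxylic acid at this position.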